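This account rests on a few compounds, and the source may have more. Where it says the series, first, only, none or still open, it means among the compounds named here.

Measured compounds:
- compound 1, `CC(C)C(Cc1ncc[nH]1)c1ccc(-c2ccc3cccc(F)c3c2)[nH]c1=O`: 22100 nM
- compound 2, `CC(C)[C@H](C[C@H]1CCNC1=O)c1ccc(-c2ccc3cccc(F)c3c2)[nH]c1=O`: 26800 nM
- compound 3, `CC(C)C(/C=C1\CCNC1=O)c1ccc(-c2ccc3cccc(F)c3c2)[nH]c1=O`: 20700 nM

In a physicochemical assay for solubility, in phosphate buffer, measured as kinetic solubility (on this read-out higher numbers stand for higher solubility and lower numbers for lower solubility), compound 1 gives 22100 nM, the second highest of the three numbers. Its nearest neighbour is compound 3, and the step of a 1.1-fold lower number from compound 1 to compound 3 (0.03 log units; within the scatter) stays within the scatter. Compound 2, with 26800 nM, also lies within the scatter of compound 1, so the three measured compounds cannot be told apart on this read-out.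

The next compound, compound 4, `CC(C)C(CC(N)=O)c1ccc(-c2ccc3cccc(F)c3c2)[nH]c1=O`, has not yet been measured. It differs from compound 1 by carbamoyl in place of 1H-imidazol-2-yl on a saturated chain carbon, two bonds along the chain from an aromatic carbon. Going by the values given here, the only measured step that touches this position is the one from compound 1 to compound 3, which exchanged one five-membered ring for another at the same place and left the number essentially unchanged. Every measured change at this position has so far fallen within the scatter, so no step beyond the scatter is expected here either. Compound 4 is therefore expected to give about 22000 nM, with a range from 11000 nM to 44000 nM. The expected step of a 1.0-fold lower number from compound 1 to compound 4 (0.00 log units; within the scatter) is estimated to stay within the scatter.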

Compound 4, solubility: 5600 nM
For compound 4 the middle estimate is 3.9-fold (0.59 log units) above the measured one, and the stated range ends above it.
By their numbers in this assay, from the lowest: compound 4; then compounds 3, 1 and 2 (each within the scatter of the next).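

In this assay, going by these compounds alone, this position proves sensitive to the group it carries: carbamoyl in place of 1H-imidazol-2-yl gives a 3.9-fold lower number from compound 1 to compound 4 (0.60 log units; beyond the scatter) and so moves the number beyond the scatter, which no step among the earlier compounds did. The open-chain group also separates from the ring-bearing group of compound 3, with a 3.7-fold lower number from compound 3 to compound 4 (0.57 log units; beyond the scatter) on the same read-out, so among these four compounds the clearly lower number belongs to the only one with no ring on this chain. Nothing measured here explains the drop.

As far as these compounds go, whether the lower number goes with losing the ring or with the carbamoyl itself stays open. A carboxylic acid, an amine or a longer chain ending in carbamoyl at this place could help to separate those two readings.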